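The compounds below may be only part of what the source reports. "The series", "measured", "known", "first", "only" and "open" are said of these compounds alone.

Measured so far:
compound 1 `Cn1nc2c(=O)n(CC3(O)CCN(Cc4ccc(-c5ccco5)cc4Cl)CC3)cnc2c1-c1ccc(CNS(C)(=O)=O)cc1` gives 65.3 nM
compound 2 `CCCNCc1ccc(-c2c3ncn(CC4(O)CCN(Cc5ccc(-c6ccco6)cc5Cl)CC4)c(=O)c3nn2C)cc1` gives 43.9 nM

In an assay on isolated protein for inhibition of ubiquitin carboxyl-terminal hydrolase 7 (Homo sapiens), with stated times of 30 min and 2 h (on this read-out higher numbers stand for weaker inhibition and lower numbers for stronger inhibition), compound 2 has the lowest of the two numbers, yet a 1.5-fold lower number from compound 1 to compound 2 (0.17 log units; within the scatter) places it within the scatter of compound 1. Compound 3 `Cn1nc2c(=O)n(CC3(O)CCN(Cc4ccc(-c5ccco5)cc4Cl)CC3)cnc2c1-c1ccc(CO)cc1` is not yet measured; it differs from compound 2 by hydroxy in place of propylamino on a saturated chain carbon bound to an aromatic carbon. Going by the values given here, the only measured step, a 1.5-fold lower number from compound 1 to compound 2 (0.17 log units; within the scatter), swaps groups on the same arm, and its small size suggests that this arm tolerates change, though no step removes the amine as here. For compound 3 the expected step is a 1.5-fold higher number from compound 2 to compound 3 (0.17 log units; within the scatter), with an estimate of 65 nM and a range from 25 nM to 170 nM.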

Compound 3, half-maximal inhibitory concentration: 42.5 nM
Compound 3: middle estimate off by 1.5-fold (0.18 log units), on the high side; the range from low to high includes it.
By their numbers in this assay, from the lowest: compounds 3, 2 and 1 (each within the scatter of the next).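

Swapping propylamino for hydroxy gives a 1.0-fold lower number from compound 2 to compound 3 (0.01 log units; within the scatter), so at this saturated chain carbon bound to an aromatic carbon, inhibition does not depend on the amine nitrogen or the propyl chain. Hydroxy in place of methanesulfonamido gives a 1.5-fold lower number from compound 1 to compound 3 (0.19 log units; within the scatter), so all three groups, despite their different atoms, read alike here. Nothing available explains why these groups read alike.

As far as these compounds go, whether a carboxylic acid or a morpholine at this place would also read alike remains open. So does whether this tolerance holds for a longer chain, such as octylamino.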